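Swapping Fluoro for Nitro on a Shared Core

The source may hold more compounds than are shown below. What is called first, only, known or untested is meant among the compounds shown, and "the series" means these compounds.

Measured so far, in a functional assay (aorta) with Rattus norvegicus as the target; on this read-out higher numbers stand for higher potency (the scale is a negative logarithm) and lower numbers for lower potency:
- compound 1, `COc1ccc(C(=O)c2ccc3c(c2)C(n2ccccc2=O)=CC(C)(C)O3)cc1`, gives 6.15
- compound 2, `CC1(C)C=C(n2ccccc2=O)c2cc(C(=O)c3ccccc3F)ccc2O1`, gives 7.08

Within the data shown here, compound 2 holds the higher of the two numbers in this assay; the only step so far, a number 0.93 log units higher from compound 1 to compound 2 (beyond the scatter), separates it from compound 1.

Compound 3, `CC1(C)C=C(n2ccccc2=O)c2cc(C(=O)c3ccccc3[N+](=O)[O-])ccc2O1`, has not yet been measured. It differs from compound 2 in one place: nitro in place of fluoro on an aromatic carbon. Put another way, the 2-fluorophenyl on the carbonyl carbon becomes a 2-nitrophenyl.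

Among the measured compounds shown here, no measured step bears directly on this change. For the measured compounds named here, the one step known, a number 0.93 log units higher from compound 1 to compound 2 (beyond the scatter), exchanged a whole substituted phenyl for another and so says nothing about fluoro against nitro on the same aromatic carbon. With no guide of that kind, the expectation for compound 3 is simply a number near that of compound 2, with a wide range: the estimated step is a number 0.18 log units lower from compound 2 to compound 3 (within the scatter), not beyond the scatter in either direction.

The estimate for compound 3 in this assay is 6.9, expected to lie between 6.2 and 7.6.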

Compound 3, logarithm of the reciprocal of the active concentration, log(1/C): 6.17
Compound 3: the middle estimate sits 0.73 log units above what was measured; measured number outside the range, below it.
By their numbers in this assay, from the lowest: compounds 1 and 3 (each within the scatter of the next); then compound 2.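

The aromatic carbon that carries fluoro in compound 2 is clearly sensitive to what sits there: in this assay, nitro in place of fluoro gives a number 0.91 log units lower from compound 2 to compound 3 (beyond the scatter) and so removes nearly all of the rise that the earlier step had shown. Having a group on that carbon is therefore not enough on its own, since the 2-nitrophenyl gives a number 0.02 log units higher from compound 1 to compound 3 (within the scatter) and cannot be told apart from the 4-methoxyphenyl, leaving compound 2 alone at the higher level among these compounds. Nothing measured here explains why fluoro and nitro differ.

The compounds shown leave open whether a chloro, a methyl or an amine on the same aromatic carbon would give a number near that of compound 2 or near that of compound 3. Also open, from the compounds shown here alone, is how a plain phenyl on the carbonyl carbon would compare, which would give the 2-fluorophenyl and the 2-nitrophenyl a common reference and show whether fluoro raises the number or nitro lowers it.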